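The compounds below may be only part of what the source reports. "The series", "measured", "known", "first", "only" and "open" are said of these compounds alone.

Of the compounds shown here, three with a shared core have been measured in a functional assay on A549 cells (Homo sapiens) for cytotoxicity, read by MTT assay, with a stated time of 72 h (on this read-out higher numbers stand for weaker inhibition and lower numbers for stronger inhibition), so far. Compound 1 `CNC(=O)c1cc(Oc2ccc(C(=O)/C=C/c3cccc(Br)c3)cc2)ccn1` gives 9940 nM and compound 3 `CNC(=O)c1cc(Oc2ccc(C(=O)/C=C/c3cc(OC)c(OC)c(OC)c3)cc2)ccn1` gives 9500 nM on this scale. Compound 2 `CNC(=O)c1cc(Oc2ccc(C(=O)/C=C/c3ccc(C#N)cc3)cc2)ccn1` gives 26400 nM as the highest number of the three, which makes it the weakest inhibitor of the set.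

The next compound is compound 4 `CNC(=O)c1cc(Oc2ccc(C(=O)/C=C/c3ccc(Cl)cc3Cl)cc2)ccn1`, which carries 2,4-dichlorophenyl in place of 4-cyanophenyl on a double-bonded chain carbon bound to a double-bonded chain carbon (in counted terms, (2,4-dichlorophenyl in place of 4-cyanophenyl on a double-bonded chain carbon bound to a double-bonded chain carbon)). For the measured compounds named here, only one measured step involves this part of the molecule and the same leaving or entering group. Putting 4-cyanophenyl in place of 3-bromophenyl gave a 2.7-fold higher number from compound 1 to compound 2 (0.42 log units; beyond the scatter) as a modest change. Compound 4 reverses that kind of swap, with a halogen-bearing ring replacing 4-cyanophenyl, so a modest move towards a lower number seems likely, though one step is thin evidence.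

The estimated change is a 2.6-fold lower number from compound 2 to compound 4 (0.42 log units; beyond the scatter) and nothing much larger is expected. For compound 4 the expected value is about 10000 nM with an estimated range from 4500 nM to 22000 nM in this read-out.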

Compound 4, half-maximal inhibitory concentration: 9460 nM
Beside the measured number, compound 4's estimate is 1.1-fold (0.02 log units) above it; the measured number falls inside the stated range.
By their numbers in this assay, from the lowest: compounds 4, 3 and 1 (each within the scatter of the next); then compound 2.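

In this assay, putting 2,4-dichlorophenyl in place of 4-cyanophenyl on a double-bonded chain carbon bound to a double-bonded chain carbon gives a 2.8-fold lower number from compound 2 to compound 4 (0.45 log units; beyond the scatter) and so adds a second step that sets the 4-cyanophenyl compound apart. Putting 2,4-dichlorophenyl in place of 3-bromophenyl at the same place gives a 1.1-fold lower number from compound 1 to compound 4 (0.02 log units; within the scatter) and so the two halogen-bearing rings cannot be told apart on this read-out. A halogen is not needed for a number in this range, since compound 3, which carries none, gives 9500 nM as its printed value.

Nothing measured here explains why the 4-cyanophenyl compound stands apart. Open, going by these compounds, is how a ring carrying an amine or a carboxylic acid would read here, and whether a single chlorine would match the two chlorines of 2,4-dichlorophenyl.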